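Exchanging methyl for methoxycarbonyl on compound 3

The source may report more compounds than this note shows. Statements on the series, on what has been measured and on what is new or still open speak of the compounds shown alone.

In a functional assay on a cell-free system (plasma, Oryctolagus cuniculus) for inhibition, with stated times of 5 min, 1 min and 6 min (a higher number here means a weaker inhibitor, a lower number a stronger inhibitor), compound 1 `CCOC(=O)c1c(C)nc(-c2cccc(C#N)c2)n1OCc1ccccc1` gives 5930 nM while compound 2 `CCOC(=O)c1c(C)nc(-c2cccc(C#N)c2)n1OCc1cccc(F)c1` gives 22400 nM and compound 3 `CCOC(=O)c1c(C)nc(-c2cccc(C#N)c2)n1OCc1ccc(C)cc1` gives 6310 nM on the same scale. Compound 3 lies within the scatter of compound 1. The remaining gap is a 3.5-fold lower number from compound 2 to compound 3 (0.55 log units; beyond the scatter) and stands out. Compound 4 `CCOC(=O)c1c(C)nc(-c2cccc(C#N)c2)n1OCc1ccc(C(=O)OC)cc1` has methoxycarbonyl in place of methyl on an aromatic carbon, para to a large group (methoxycarbonyl in place of methyl on an aromatic carbon). Within the data shown here, two steps bear on this: methyl in place of hydrogen gave a 1.1-fold higher number from compound 1 to compound 3 (0.03 log units; within the scatter) whereas fluoro in place of hydrogen gave a 3.8-fold higher number from compound 1 to compound 2 (0.58 log units; beyond the scatter) on the same ring. Neither step involves methoxycarbonyl, so only a small rise in this assay is expected, possibly none beyond the scatter. The expected change is a 1.4-fold higher number from compound 3 to compound 4 (0.15 log units; within the scatter) at the middle of the estimate. Compound 4 is estimated at 9000 nM with an expected range of 3000 nM to 27000 nM overall.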

Compound 4, half-maximal inhibitory concentration: 9470 nM
Compound 4: the middle estimate sits 1.1-fold (0.02 log units) below what was measured; the measured number falls inside the stated range.
By their numbers in this assay, from the lowest: compounds 1, 3 and 4 (each within the scatter of the next); then compound 2.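

Methoxycarbonyl, which brings two hydrogen-bond acceptors, can replace methyl on this aromatic carbon, para to a large group, with a 1.5-fold higher number from compound 3 to compound 4 (0.18 log units; within the scatter) in this assay and with a 1.6-fold higher number from compound 1 to compound 4 (0.20 log units; within the scatter) against the unsubstituted ring. Compound 2 stays apart from this ester, with a 2.4-fold lower number from compound 2 to compound 4 (0.37 log units; beyond the scatter). Nothing available explains these numbers. From the compounds shown here alone, whether a carboxylic acid or an amine on this carbon would stay as close to compound 3 remains open. So does the effect of methoxycarbonyl on the ring carbon that carries fluoro in compound 2.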